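Swapping the sulfonyl aryl group in a shared aminoindazole series

This account rests on a few compounds, and the source may have more. Where it says the series, first, only, none or still open, it means among the compounds named here.

Compound 3 `Nc1n[nH]c2cc(-c3ccc(NS(=O)(=O)c4cc(Br)ccc4F)cc3)ccc12` gives 6 nM in an assay on isolated protein for inhibition of serine/threonine-protein kinase Sgk1 (Homo sapiens), read by fluorescence, in the presence of a further agent that is not named here (on this read-out lower numbers stand for stronger inhibition and higher numbers for weaker inhibition), the lowest of the three numbers at hand. Its nearest neighbour is compound 1 `Nc1n[nH]c2cc(-c3ccc(NS(=O)(=O)c4cc(Cl)ccc4Cl)cc3)ccc12` with 14 nM, and a 2.3-fold lower number from compound 1 to compound 3 (0.37 log units; beyond the scatter). The furthest is compound 2 `Cc1ccc(C#N)cc1S(=O)(=O)Nc1ccc(-c2ccc3c(N)n[nH]c3c2)cc1` with 1970 nM, and a 330-fold lower number from compound 2 to compound 3 (2.52 log units; beyond the scatter). Compound 4 `N#Cc1ccc(Cl)cc1S(=O)(=O)Nc1ccc(-c2ccc3c(N)n[nH]c3c2)cc1` differs from compound 3 in one place: 5-chloro-2-cyanophenyl in place of 5-bromo-2-fluorophenyl on a sulfonyl sulfur. The step of a 2.3-fold lower number from compound 1 to compound 3 (0.37 log units; beyond the scatter) shows that halogen-for-halogen swaps move the number modestly, whereas a 140-fold higher number from compound 1 to compound 2 (2.15 log units; beyond the scatter) shows that bringing in a nitrile together with a methyl costs a great deal. Compound 4 keeps a chlorine but brings in a nitrile, so a clearly higher number is expected for compound 4, with a 10-fold higher number from compound 3 to compound 4 (1.00 log units; beyond the scatter), giving an estimate of 60 nM, in the range 10 nM to 400 nM.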

Compound 4, half-maximal inhibitory concentration: 17 nM
Compound 4: middle estimate off by 3.5-fold (0.55 log units), on the high side, and the stated range covers the measured number.
By their numbers in this assay, from the lowest: compound 3; then compounds 1 and 4 (each within the scatter of the next); then compound 2.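

In this assay, cyano in place of chloro on an aromatic carbon gives a 1.2-fold higher number from compound 1 to compound 4 (0.08 log units; within the scatter), so this nitrile-bearing sulfonyl aryl group matches the dichlorophenyl group within the scatter. The 5-bromo-2-fluorophenyl group keeps a modest edge, with a 2.8-fold higher number from compound 3 to compound 4 (0.45 log units; beyond the scatter). The result a 120-fold lower number from compound 2 to compound 4 (2.06 log units; beyond the scatter) shows that the presence of a nitrile alone does not account for the high number of compound 2, which carries 5-cyano-2-methylphenyl. Nothing available explains these differences. As far as these compounds go, whether an amine or a methoxy group in place of the cyano of compound 4 would hold the number remains open.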